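The compounds below may be only part of what the source reports. "The series", "measured", "known", "first", "only" and "open" are said of these compounds alone.

Measured compounds:
- compound 1 `Ic1ccc(C2CC(c3ccc4c(c3)OCCO4)=NN2c2ccccc2)cc1`: 3470 nM
- compound 2 `Oc1ccccc1C1CC(c2ccc(Cl)c(Cl)c2)=NN1c1ccccc1`: 1570 nM

Of the compounds shown here, two have been measured in a functional assay on WM 266-4 cells (Homo sapiens) for antiproliferative activity, read by MTT assay, with a stated time of 24 h; on this read-out lower numbers stand for stronger inhibition of growth and higher numbers for weaker inhibition of growth. Compound 1 gives 3470 nM, and compound 2 gives 1570 nM. Compound 1 therefore stands with the highest of the two numbers, and its nearest neighbour, compound 2, lies at a lower number, a gap that falls beyond the usual scatter of this assay. For the measured compounds named here, no pair of measured compounds differs in only one place, so no single structural change has yet been tied to a measured step.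

Compound 3 `Fc1ccc(C2CC(c3ccc4c(c3)OCCO4)=NN2c2ccccc2)cc1` has not been measured. It differs from compound 1 in one place: fluoro in place of iodo on an aromatic carbon. Taken one bond further out, the change reads as 4-iodophenyl to 4-fluorophenyl.

Nothing in the two measured compounds speaks to this exchange, so the expectation rests on compound 1 alone. The step from compound 1 to compound 3 in this assay is expected to be small, if anything in the direction of a higher number, and quite possibly within the scatter; the estimate is a 1.3-fold higher number from compound 1 to compound 3 (0.11 log units; within the scatter). Compound 3 is accordingly estimated at 4500 nM, with a range from 1500 nM to 14000 nM.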

Compound 3, concentration for 50% growth inhibition: 6050 nM
Compound 3: middle estimate off by 1.3-fold (0.13 log units), on the low side; measured number inside the range.
By their numbers in this assay, from the lowest: compound 2; then compounds 1 and 3 (each within the scatter of the next).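

In this assay, the first step read at this position is a 1.7-fold higher number from compound 1 to compound 3 (0.24 log units; within the scatter), with fluoro in place of iodo on an aromatic carbon, para to a large group. This step lies within the usual scatter, so the 4-iodophenyl and 4-fluorophenyl forms cannot be told apart on this read-out, and with the rest of the core of compound 1 held fixed, this pair shows that one halogen can stand in for the other without a step beyond the scatter. Nothing measured here bears on why the two compounds read so alike.

The compounds shown leave open whether a group other than a halogen at this place, such as an amine, a methoxy group or a carboxylic acid, or plain hydrogen, would also stay within the scatter of compound 1 or would give a clear step in either direction. They also leave open whether the exchange of iodo for fluoro would read the same if another part of the core were altered, since this single pair offers only one setting for it.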